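Trimming one methyl from the acid-bearing carbon

The source may hold more compounds than are shown below. What is called first, only, known or untested is meant among the compounds shown, and "the series" means these compounds.

Measured compounds and their values:
- compound 1 `CCC(C(=O)O)c1nn(Cc2cn3cc(OCC4CC4)c(Cl)cc3n2)c2ccccc2c1=O`: 5.6 nM
- compound 2 `CC(C)(C(=O)O)c1nn(Cc2cn3cc(OCC4CC4)c(Cl)cc3n2)c2ccccc2c1=O`: 21 nM
- compound 3 `O=C(O)Cn1nc(Cc2cn3cc(OCC4CC4)c(Cl)cc3n2)c2ccccc2c1=O`: 7.6 nM

These three compounds were tested in a functional assay on HFL1 cells for antagonist activity at sphingosine 1-phosphate receptor 2 (Homo sapiens), read by ELISA, with a stated time of 24 h; on this read-out lower numbers stand for stronger inhibition and higher numbers for weaker inhibition. Compound 2 stands with the highest of the three numbers, meaning it is the weakest inhibitor here; compound 3 sits nearest, and compound 1 furthest, both beyond the scatter. The single change tracked so far runs from compound 1 to compound 2, where 1-carboxy-1-methylethyl replaced 1-carboxypropyl and the number rose, as shown by a 3.8-fold higher number from compound 1 to compound 2 (0.57 log units; beyond the scatter).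

Compound 4 `C[C@H](C(=O)O)c1nn(Cc2cn3cc(OCC4CC4)c(Cl)cc3n2)c2ccccc2c1=O` is not yet measured. It differs from compound 2 as follows: 1-carboxyethyl in place of 1-carboxy-1-methylethyl on an aromatic carbon. In effect, one methyl is removed from the carbon that carries the acid, leaving a single defined stereocentre, so the carbon once again bears a hydrogen as it does in compound 1.

The step from compound 1 to compound 2 is the one that bears on this: adding a methyl there gave a modest rise in the number. Removing a methyl is expected to do the reverse, so compound 4 is expected to show a lower number than compound 2 in this assay, by a step of about a 3.0-fold lower number from compound 2 to compound 4 (0.48 log units; beyond the scatter). The estimate for compound 4 is 7 nM, within a range from 3 nM to 20 nM.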

Compound 4, half-maximal inhibitory concentration: 2.1 nM
Compound 4: the middle estimate sits 3.3-fold (0.52 log units) above what was measured, and the stated range ends above it.
By their numbers in this assay, from the lowest: compound 4; then compounds 1 and 3 (each within the scatter of the next); then compound 2.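

In this assay the carbon that carries the acid proves highly sensitive to a single methyl: exchanging 1-carboxy-1-methylethyl for 1-carboxyethyl gives a 10-fold lower number from compound 2 to compound 4 (1.00 log units; beyond the scatter) and so shows that a hydrogen and one methyl on this carbon serve better than two methyls. The 1-carboxyethyl group also outperforms 1-carboxypropyl, with a 2.7-fold lower number from compound 1 to compound 4 (0.43 log units; beyond the scatter) and thus weaker inhibition for both larger groups, although this comparison also includes the defined stereocentre of compound 4, which compound 1 is not drawn with. Nothing available explains why these small changes shift the number.

The mirror-image form of compound 4 remains an open question, so the share of the gain that depends on the arrangement at this stereocentre cannot be separated from the share that depends on chain size. Also open, from the compounds shown here alone, is how this position would respond to a primary amide in place of the carboxylic acid, or to a cyclopropane ring joining the two methyls of compound 2.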